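This account rests on a few compounds, and the source may have more. Where it says the series, first, only, none or still open, it means among the compounds named here.

Compound 2 `COc1cc(N)c(Cl)cc1NC(=O)C1CCN(Cc2cccc(C#N)c2)CC1` carries a 3-cyanobenzyl group on a saturated chain carbon bound to an amine nitrogen in a ring. In a functional assay on the whole organism for antagonist activity, with Mus musculus as the target (a lower number here means that less compound is needed, a higher number that more compound is needed for the effect), compound 2 reaches only the limit of the measurement, > 4 mg/kg, so no number is known for it. Compound 1 `CCCCCCCN1CCC(C(=O)Nc2cc(Cl)c(N)cc2OC)CC1`, which carries a heptyl chain on that saturated chain carbon, likewise stops at a limit in this assay, giving > 10 mg/kg. The step between them, a step that the two limits leave unreadable from compound 1 to compound 2, cannot be read, because both the limit of > 10 mg/kg in this assay, at which 1 of the 2 values shown sits, and the limit of > 4 mg/kg in this assay, at which 1 of the 2 values shown sits, are limits rather than numbers. Compound 3 `CCCCN1CCC(C(=O)Nc2cc(Cl)c(N)cc2OC)CC1` is the next change from compound 2: propyl in place of 3-cyanophenyl on a saturated chain carbon bound to an amine nitrogen in a ring. Only the unreadable step from compound 1 to compound 2 bears on this change, and it sets neither size nor direction. Since compound 1 with a plain chain at this place gave only the limit > 10 mg/kg, compound 3 with its butyl chain is expected to sit near the limits as well. Compound 3 is estimated at 10 mg/kg in this assay, between 3 mg/kg and 30 mg/kg. The estimated step from compound 2 to compound 3, a step that the limit leaves unreadable from compound 2 to compound 3, is expected to be none beyond the scatter.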

Compound 3, dose for half-maximal effect: > 10 mg/kg
Compound 3 gave a limit, no number; the forecaster's own chance of this, stated with the estimate: 70%; the middle value lies on the limit itself.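

In this assay compound 3 stops at a limit, > 10 mg/kg, and not at a number. Among these compounds, no step among compound 1, compound 2 and compound 3 can be read. The compounds shown leave open what dose any of them needs for the effect, and whether the butyl chain and the 3-cyanobenzyl group differ at all.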